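Fluoronitrophenyl in Place of the Cyanophenyl Ether

The source may hold more compounds than are shown below. What is called first, only, known or untested is meant among the compounds shown, and "the series" means these compounds.

Compound 1 `CC(C)[C@H](NC(=O)COc1cccc2ccccc12)C(=O)N[C@@H](CC(=O)O)C(=O)COc1ccc(C#N)cc1` carries the highest number of the three measured compounds in a functional assay with Homo sapiens as the target; a lower number here means a stronger inhibitor, a higher number a weaker inhibitor: compound 1 gives 26700 nM. Its two neighbours share the same core and differ only in the group on the oxygen on a saturated carbon. Compound 2 `CC(C)[C@H](NC(=O)COc1cccc2ccccc12)C(=O)N[C@@H](CC(=O)O)C(=O)COc1ccc(F)cc1F` gives 17600 nM, and compound 3 `CC(C)[C@H](NC(=O)COc1cccc2ccccc12)C(=O)N[C@@H](CC(=O)O)C(=O)COc1cc(F)ccc1F` gives 19700 nM. The steps are small, a 1.5-fold lower number from compound 1 to compound 2 (0.18 log units; within the scatter) and a 1.4-fold lower number from compound 1 to compound 3 (0.13 log units; within the scatter), and between the two difluorophenyl compounds the step is a 1.1-fold higher number from compound 2 to compound 3 (0.05 log units; within the scatter), so all three numbers sit together within the scatter and no order among them can be claimed.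

Compound 4 `CC(C)[C@H](NC(=O)COc1cccc2ccccc12)C(=O)N[C@@H](CC(=O)O)C(=O)COc1ccc([N+](=O)[O-])cc1F` is not yet measured. It differs from compound 1 at the same place where compounds 2 and 3 differ from it: 2-fluoro-4-nitrophenyl in place of 4-cyanophenyl on an oxygen on a saturated carbon. The two measured steps at this position, both exchanging 4-cyanophenyl for a difluorophenyl, stayed within the scatter, and nothing else bears on the change. On that basis a reader of these numbers would expect no step beyond the scatter, a 1.3-fold lower number from compound 1 to compound 4 (0.10 log units; within the scatter). Compound 4 is therefore estimated at 21000 nM, with a range from 8000 nM to 55000 nM.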

Compound 4, half-maximal inhibitory concentration: 15800 nM
The estimate for compound 4 lay 1.3-fold (0.12 log units) above the measured number; low and high end bracket the measured number.
By their numbers in this assay, from the lowest: compounds 4, 2, 3 and 1 (each within the scatter of the next).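

In this assay, 2-fluoro-4-nitrophenyl joins the difluorophenyl groups on the oxygen on a saturated carbon without a step beyond the scatter, with a 1.7-fold lower number from compound 1 to compound 4 (0.23 log units; within the scatter) as the step from the 4-cyanophenyl compound. The comparison with the difluorophenyl compounds adds a direct exchange on the ring, nitro in place of fluoro on an aromatic carbon, and a 1.1-fold lower number from compound 2 to compound 4 (0.05 log units; within the scatter) shows that this exchange leaves the number within the scatter, as does a 1.2-fold lower number from compound 3 to compound 4 (0.10 log units; within the scatter) for the change from 2,5-difluorophenyl. No measurement here accounts for how closely these numbers sit together.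

As far as these compounds go, all four compounds carry a substituted phenyl at this place, so the effect of a plain phenyl remains open. So does whether a group with no aromatic ring, such as an amine or a carboxylic acid on a longer chain, would produce a step beyond the scatter.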